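Aryl amide in place of cyclopropyl amide

This account rests on a few compounds, and the source may have more. Where it says the series, first, only, none or still open, it means among the compounds named here.

Compound 2 `O=C(Nc1c(C(O)(C(F)(F)F)C(F)(F)F)ccc2ccccc12)C1CC1` gives 751 nM in an assay on LtK cells with ATP-sensitive inward rectifier potassium channel 11 (Homo sapiens) as the target (on this read-out higher numbers stand for an effect only at larger amounts of compound and lower numbers for an effect already at smaller amounts), the highest of the two numbers available; its nearest neighbour, compound 1 `C/C=C/C(=O)Nc1c(C(O)(C(F)(F)F)C(F)(F)F)ccc2ccccc12`, gives 72 nM. Among the compounds with values here, the only measured step is a 10-fold higher number from compound 1 to compound 2 (1.02 log units; beyond the scatter). Compound 3 `Cc1ccccc1C(=O)Nc1c(C(O)(C(F)(F)F)C(F)(F)F)ccc2ccccc12` differs from compound 2 by 2-methylphenyl in place of cyclopropyl on a carbonyl carbon. Within the data shown here, no measured step covers a 2-methylphenyl at this carbonyl carbon, so the one known step shows only that this substituent moves the number strongly. A moderate fall toward compound 1 is expected, a 3.0-fold lower number from compound 2 to compound 3 (0.48 log units; beyond the scatter), with the direction uncertain. Compound 3 is therefore estimated at 250 nM, range 50 nM to 1200 nM.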

Compound 3, half-maximal effective concentration: 5550 nM
Compound 3: middle estimate off by 22-fold (1.35 log units), on the low side, and the stated range ends below it.
By their numbers in this assay, from the lowest: compound 1; then compound 2; then compound 3.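

Exchanging cyclopropyl for 2-methylphenyl on the carbonyl carbon gives in this assay a 7.4-fold higher number from compound 2 to compound 3 (0.87 log units; beyond the scatter), so the aromatic group brings no gain at this position. Against prop-1-en-1-yl the same group gives a 77-fold higher number from compound 1 to compound 3 (1.89 log units; beyond the scatter), and the order from the lowest number is now prop-1-en-1-yl, cyclopropyl, 2-methylphenyl. Nothing available explains this order.

Still open, going by these compounds, is whether a phenyl without the methyl would behave like 2-methylphenyl, which would separate the ring from its methyl. A longer chain or an amine on this carbonyl carbon also remains to be placed in the order.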